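This account rests on a few compounds, and the source may have more. Where it says the series, first, only, none or still open, it means among the compounds named here.

The series shares the core seen in compound 1 `O=C1O[C@H]([C@@H](O)Cn2cc(C3CC3)nn2)C(OCc2ccccc2)=C1OCc1ccccc1` and compound 2 `O=C1O[C@H]([C@@H](O)Cn2cc(CNS(=O)(=O)c3ccc(Cl)cc3)nn2)C(OCc2ccccc2)=C1OCc1ccccc1`; compound 3 `COc1ccc(-c2cn(C[C@H](O)[C@H]3OC(=O)C(OCc4ccccc4)=C3OCc3ccccc3)nn2)cc1` is not yet measured. In a functional assay on SW-620 cells (Homo sapiens) for antiproliferative activity, read by MTT assay, with a stated time of 72 h (on this read-out higher numbers stand for weaker inhibition and lower numbers for stronger inhibition), compound 1 gives 54200 nM, and in this assay compound 2 gives 18000 nM. Within the data shown here, compound 2 thus holds the lowest of the two numbers so far, the only step to it being a 3.0-fold lower number from compound 1 to compound 2 (0.48 log units; beyond the scatter). The change now in view is 4-methoxyphenyl in place of (((4-chlorophenyl)sulfonyl)amino)methyl on an aromatic carbon. Among the measured compounds shown here, only one measured step bears on it, a 3.0-fold lower number from compound 1 to compound 2 (0.48 log units; beyond the scatter), and it concerns a different exchange at the same carbon; it shows that the group on that carbon can move the number beyond the scatter, but gives no direction for trading the hydrogen-bond donor and the sulfonyl for an aromatic ring. The expectation is therefore a step of a 1.4-fold higher number from compound 2 to compound 3 (0.14 log units; within the scatter), essentially no change, with wide uncertainty. Compound 3 is estimated at 25000 nM, with a range from 8000 nM to 80000 nM.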

Compound 3, half-maximal inhibitory concentration: 58200 nM
The estimate for compound 3 lay 2.3-fold (0.37 log units) below the measured number, and the stated range covers the measured number.
By their numbers in this assay, from the lowest: compound 2; then compounds 1 and 3 (each within the scatter of the next).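

In this assay the exchange at the aromatic carbon gives a 3.2-fold higher number from compound 2 to compound 3 (0.51 log units; beyond the scatter) so 4-methoxyphenyl does not retain the lower number reached with (((4-chlorophenyl)sulfonyl)amino)methyl. Set against cyclopropyl, the same group gives a 1.1-fold higher number from compound 1 to compound 3 (0.03 log units; within the scatter) which leaves these two groups indistinguishable here and makes (((4-chlorophenyl)sulfonyl)amino)methyl the only one of the three substituents with steps beyond the scatter to both others. Nothing available accounts for this difference.

Still open is which part of (((4-chlorophenyl)sulfonyl)amino)methyl carries the step, whether the sulfonyl, the amino hydrogen or the 4-chlorophenyl ring, as the compounds shown change these together. Also open, going by these compounds, is how a carboxylic acid, an amine or a longer chain ending in 4-chlorophenyl would read on this carbon.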